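Chain extension at the saturated ring carbon: methyl, ethyl, propyl

The source may report more compounds than this note shows. Statements on the series, on what has been measured and on what is new or still open speak of the compounds shown alone.

Measured compounds:
compound 1, `CC1(c2ccccc2)CC(=O)C(C(CC(=O)c2ccc(-c3ccc(Br)cc3)cc2)c2ccccc2)=C(O)O1`, 6730 nM
compound 2, `CCC1(c2ccccc2)CC(=O)C(C(CC(=O)c2ccc(-c3ccc(Br)cc3)cc2)c2ccccc2)=C(O)O1`, 6590 nM

Compound 1 and compound 2 share a core and differ only by methyl in place of hydrogen on a saturated chain carbon bound to a saturated ring carbon. In a functional assay on XF498 cells (Homo sapiens) for inhibition, with a stated time of 72 h (on this read-out lower numbers stand for stronger inhibition and higher numbers for weaker inhibition), compound 1 gives 6730 nM, and compound 2 gives 6590 nM; the step of a 1.0-fold lower number from compound 1 to compound 2 (0.01 log units; within the scatter), so the two numbers are within the scatter of each other, and compound 2 stands level with compound 1.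

Compound 3, `CCCC1(c2ccccc2)CC(=O)C(C(CC(=O)c2ccc(-c3ccc(Br)cc3)cc2)c2ccccc2)=C(O)O1`, extends the chain once more: methyl in place of hydrogen on a saturated chain carbon, two bonds along the chain from a saturated ring carbon. Among the measured compounds shown here, the only step that bears on it is the one from compound 1 to compound 2, which was within the scatter, so for compound 3 no step beyond the scatter is expected in this assay, in either direction. Compound 3 is therefore estimated at 6400 nM, with a range from 3000 nM to 13500 nM, which means an expected step of a 1.0-fold lower number from compound 2 to compound 3 (0.01 log units; within the scatter).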

Compound 3, half-maximal inhibitory concentration: > 10000 nM
Compound 3: only a limit was reported; the forecaster's own chance of this, stated with the estimate: 3%; middle value at least 1.5-fold (0.19 log units) away from the limit.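

In this assay compound 3 gives > 10000 nM, which is a limit of the assay and not a number. Going from ethyl to propyl gives an at least 1.5-fold higher number from compound 2 to compound 3 (0.18 log units; that floor lies within the scatter), and the full extension gives an at least 1.4-fold higher number from compound 1 to compound 3 (0.17 log units; that floor lies within the scatter); both floors lie within the scatter, so the limit alone does not establish that compound 3 is weaker, though its true value could lie well beyond them. This position, where methyl to ethyl changed nothing beyond the scatter, therefore need not stay as tolerant for the next carbon, and the only basis for that caution is a single compound at the limit: the limit of > 10000 nM in this assay, at which 1 of the 3 values shown sits.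

As far as these compounds go, how far compound 3 really lies from compound 2 stays open. So does whether a longer chain such as butyl, or a hydroxyl or an amine at the chain end, would behave like propyl.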